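The source may hold more compounds than are shown below. What is called first, only, known or untested is meant among the compounds shown, and "the series" means these compounds.

In a functional assay for inhibition (a higher number here means a weaker inhibitor, a lower number a stronger inhibitor), compound 1 (`CC(C)(C)c1cc(-c2cc(=O)c3ccc(OCCO)cc3o2)cc(C(C)(C)C)c1O`) gives 3000 nM, compound 2 (`CC(C)(C)c1cc(-c2cc(=O)c3ccccc3o2)cc(C(C)(C)C)c1O`) gives 3000 nM and compound 3 (`CCOC(=O)CCCCOc1ccc2c(=O)cc(-c3cc(C(C)(C)C)c(O)c(C(C)(C)C)c3)oc2c1`) gives 3000 nM. Compound 3 therefore stands level with the other two, with nothing separating the three.

The next entry is compound 4 (`COc1ccc2c(=O)cc(-c3cc(C(C)(C)C)c(O)c(C(C)(C)C)c3)oc2c1`). The change is hydrogen in place of 3-(ethoxycarbonyl)propyl on a saturated chain carbon bound to an oxygen on an aromatic ring. In words, hydrogen takes the place of 3-(ethoxycarbonyl)propyl on a saturated chain carbon bound to an oxygen on an aromatic ring, which also reads as 4-(ethoxycarbonyl)butoxy to methoxy.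

All three measured steps bear on this change. The closest is no change at the digits printed from compound 2 to compound 3 (within the scatter), where 4-(ethoxycarbonyl)butoxy replaces hydrogen. Replacing 2-hydroxyethoxy with hydrogen gives no change at the digits printed from compound 1 to compound 2 (within the scatter), and extending that chain to the ester gives no change at the digits printed from compound 1 to compound 3 (within the scatter). Among the compounds with values here, none of the three steps goes beyond the scatter, although only three compounds support this reading and none of them carries methoxy.

No step beyond the scatter is therefore expected in this assay, in either direction. The expected change is no change at the digits printed from compound 3 to compound 4 (within the scatter). Compound 4 is estimated at 3000 nM, with an expected range of 1500 nM to 6000 nM.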

Compound 4, half-maximal inhibitory concentration: 1000 nM
For compound 4 the middle estimate is 3.0-fold (0.48 log units) above the measured one; the whole stated range lies above it.
By their numbers in this assay, from the lowest: compound 4; then compounds 1, 2 and 3 (each within the scatter of the next).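

In this assay, the aromatic carbon carrying these ethers can shift the number, but the outcome depends on the group: methoxy in place of hydrogen gives a step beyond the scatter (a 3.0-fold lower number from compound 2 to compound 4 (0.48 log units; beyond the scatter)), whereas 4-(ethoxycarbonyl)butoxy in place of hydrogen does not (no change at the digits printed from compound 2 to compound 3 (within the scatter)). Cutting the ester chain back to methoxy (a 3.0-fold lower number from compound 3 to compound 4 (0.48 log units; beyond the scatter)) and replacing 2-hydroxyethoxy with methoxy (a 3.0-fold lower number from compound 1 to compound 4 (0.48 log units; beyond the scatter)) give steps beyond the scatter too, so among these four compounds only methoxy separates from the unsubstituted compound 2, and compounds 1 and 3 go against any reading that an ether at this place is enough on its own. Nothing measured here accounts for the difference between methoxy and the two longer chains.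

Still open, on these data alone, is whether ethoxy or propoxy keeps the number of compound 4 or returns to the level of compounds 1 and 3, which would show how far the chain can grow. Also open, as far as these compounds go, is how a free carboxylic acid or a terminal dimethylamino group on the chain would compare with the ethyl ester of compound 3.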